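The source may hold more compounds than are shown below. What is called first, only, known or untested is meant among the compounds shown, and "the series" means these compounds.

In a functional assay on TM4 cells (Mus musculus) for cytotoxicity, read by MTT assay, with a stated time of 72 h (on this read-out lower numbers stand for stronger inhibition and higher numbers for weaker inhibition), compound 1 `Nc1nc(NC2CCCCC2)sc1C(=O)c1ccccc1` gives 9300 nM, compound 2 `Nc1nc(Nc2ccccc2)sc1C(=O)c1cccnc1` gives 5500 nM and compound 3 `Nc1nc(Nc2ccc(S(N)(=O)=O)cc2)sc1C(=O)c1cccnc1` gives 13000 nM. Compound 3 thus lies within the scatter of compound 1, while its number is higher than that of compound 2 by more than the scatter. Compound 4 `Nc1nc(Nc2ccc(S(N)(=O)=O)cc2)sc1C(=O)c1ccccc1` has phenyl in place of pyridin-3-yl on a carbonyl carbon. Going by the values given here, the only measured step, a 2.4-fold higher number from compound 2 to compound 3 (0.37 log units; beyond the scatter), adds the sulfamoyl group, which stays unchanged here, and no measured pair isolates this swap. Compound 1 also carries phenyl but differs elsewhere as well. With no evidence for a shift in either direction, no change beyond the scatter is expected in this assay. The expected step is a 1.2-fold lower number from compound 3 to compound 4 (0.07 log units; within the scatter). For compound 4 the estimated value is 11000 nM, with an expected range from 5000 nM to 25000 nM.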

Compound 4, half-maximal inhibitory concentration: 9100 nM
Estimate against measurement, compound 4: 1.2-fold (0.08 log units) above; low and high end bracket the measured number.
By their numbers in this assay, from the lowest: compounds 2, 4, 1 and 3 (each within the scatter of the next, the first and the last beyond it).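

In this assay, going by these compounds alone, the change of pyridin-3-yl to phenyl on a carbonyl carbon gives a 1.4-fold lower number from compound 3 to compound 4 (0.15 log units; within the scatter) and is the first measured swap at this position. With the sulfamoyl group present, the nitrogen of the pyridin-3-yl ring is thus not needed to keep the number within the scatter, and this single pair shows no gain or loss from it. No available evidence bears on this result. From the compounds shown here alone, whether the swap reads the same without the sulfamoyl group remains open. So does the effect of an amine or a carboxylic acid on the phenyl ring.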